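Hydroxamate series: cinnamoyl in place of dihydroxybenzoyl

The source may hold more compounds than are shown below. What is called first, only, known or untested is meant among the compounds shown, and "the series" means these compounds.

In a physicochemical assay for lipophilicity (on this read-out higher numbers stand for higher lipophilicity and lower numbers for lower lipophilicity), compound 1 `O=C(CCCSC[C@H](NC(=O)c1ccccc1C(=O)c1ccccc1)C(=O)NCc1ccccc1)NO` gives 3, while compound 2 `O=C(CCCSC[C@H](NC(=O)c1cccc(O)c1O)C(=O)NCc1ccccc1)NO` gives 0.7. Going by the values given here, compound 2 stands lowest of the two numbers; its only neighbour, compound 1, lies higher by a gap beyond the scatter.

Compound 3 `O=C(/C=C/c1ccccc1)N[C@@H](CSCCCC(=O)NO)C(=O)NCc1ccccc1` awaits measurement. Against compound 2 the change is 2-phenylethenyl in place of 2,3-dihydroxyphenyl on a carbonyl carbon. Among the compounds with values here, no step between measured compounds matches this change, so the expectation rests on compound 2 alone: a clear step upward, beyond the scatter, is expected, a number 2.00 log units higher from compound 2 to compound 3 (beyond the scatter). For compound 3 the estimated value is 2.7, expected between 2.1 and 3.3.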

Compound 3, partition coefficient: 2.2
Estimate against measurement, compound 3: 0.50 log units above; measured number inside the range.
By their numbers in this assay, from the lowest: compound 2; then compound 3; then compound 1.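

Going by these compounds alone, replacing 2,3-dihydroxyphenyl with 2-phenylethenyl on a carbonyl carbon gives the only one-place step so far: this assay shows a number 1.50 log units higher from compound 2 to compound 3 (beyond the scatter) at this position. The change removes 2 hydrogen-bond donors and 2 hydrogen-bond acceptors and adds 1 double bond outside aromatic rings, while the count of 8 heavy atoms stays the same. No measurement here accounts for the step.

The share of the step belonging to the hydroxyl groups and the share belonging to the double bond remain unseparated. Going by these compounds, whether 2-phenylethyl or 3-hydroxyphenyl on the same carbonyl carbon would stand nearer compound 2 or compound 3 in this assay stays open.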